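The source may report more compounds than this note shows. Statements on the series, on what has been measured and on what is new or still open speak of the compounds shown alone.

In a functional assay on MCF7 cells (Homo sapiens) for antiproliferative activity, read by MTT assay, with a stated time of 72 h (on this read-out higher numbers stand for weaker inhibition and lower numbers for stronger inhibition), compound 1 `COc1cc2ncnc(N3CCc4ccccc43)c2cc1NC(=O)/C=C/CN(C)C` gives 3370 nM. Compound 2 `CCN(CC)C/C=C/C(=O)Nc1cc2c(N3CCc4ccccc43)ncnc2cc1OC` carries one change on the same core, (diethylamino in place of dimethylamino on a saturated chain carbon bound to a double-bonded chain carbon), and in this assay compound 2 gives 1990 nM, which is a 1.7-fold lower number from compound 1 to compound 2 (0.23 log units; within the scatter). Compound 3 `CN(C)C/C=C/C(=O)Nc1cc2c(N3CCc4ccccc43)ncnc2cc1O[C@@H]1CCOC1` differs from compound 1 in another way, (oxolan-3-yl in place of methyl on an oxygen on an aromatic ring), and in this assay compound 3 gives 1340 nM, a step of a 2.5-fold lower number from compound 1 to compound 3 (0.40 log units; beyond the scatter). Compound 4 `CCN(CC)C/C=C/C(=O)Nc1cc2c(N3CCc4ccccc43)ncnc2cc1O[C@@H]1CCOC1` has not been measured; it differs from compound 3 by diethylamino in place of dimethylamino on a saturated chain carbon bound to a double-bonded chain carbon, the same change at the same place that led from compound 1 to compound 2, seen twice among these compounds. Because the earlier step was a 1.7-fold lower number from compound 1 to compound 2 (0.23 log units; within the scatter), a step of similar size, a 1.7-fold lower number from compound 3 to compound 4 (0.22 log units; within the scatter), is expected here. Compound 4 is therefore estimated to give 800 nM in this assay, plausibly between 400 nM and 1600 nM.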

Compound 4, half-maximal inhibitory concentration: 4980 nM
The estimate for compound 4 lay 6.2-fold (0.79 log units) below the measured number; the measured number lies above the stated range.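

The swap of dimethylamino for diethylamino did not carry over between cores in this assay: with the oxolan-3-yl group in place it gave a 3.7-fold higher number from compound 3 to compound 4 (0.57 log units; beyond the scatter) and so ran opposite to the earlier step: the same change on two cores in this assay, a 1.7-fold lower number (0.23 log units; within the scatter) from compound 1 to compound 2 and a 3.7-fold higher number (0.57 log units; beyond the scatter) from compound 3 to compound 4, 6.3-fold (0.80 log units) apart, beyond the scatter of two such steps. The oxolan-3-yl change reversed in the same way, giving a 2.5-fold higher number from compound 2 to compound 4 (0.40 log units; beyond the scatter) once diethylamino was present: the same change on two cores in this assay, a 2.5-fold lower number (0.40 log units; beyond the scatter) from compound 1 to compound 3 and a 2.5-fold higher number (0.40 log units; beyond the scatter) from compound 2 to compound 4, 6.3-fold (0.80 log units) apart, beyond the scatter of two such steps. Across these four compounds, then, the effect of each change depends on the other, so a step read on one core is a poor guide to the next, though this does not show why, or whether it holds beyond them.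

Still open, as far as these compounds go, is how a ring amine such as piperidine or morpholine would behave on either core. The same goes for a longer chain on the oxygen, such as 2-methoxyethyl.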